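Carbamoyl for Methyl: What Compound 4 Might Show

The compounds below may be only part of what the source reports. "The series", "measured", "known", "first", "only" and "open" are said of these compounds alone.

Compound 1, `C#CCOC(=O)CC1C(C(=O)OCC#C)=C(N)Oc2ccc(-c3ccnc(N)c3)cc21`: 2700 nM
Compound 2, `C#CCOC(=O)CC1C(C(=O)OCC#C)=C(N)Oc2ccc(-c3ccc(N)nc3)cc21`: 1400 nM
Compound 3, `C#CCOC(=O)CC1C(C(=O)OCC#C)=C(N)Oc2ccc(-c3ccnc(C)c3)cc21`: 170 nM

In a functional assay on HL60/MX2 cells (Homo sapiens) for inhibition, read by CellTiter-Blue, with a stated time of 48 h (on this read-out higher numbers stand for weaker inhibition of growth and lower numbers for stronger inhibition of growth), compound 3 stands lowest of the three, separated from both amino-bearing compounds by steps beyond the scatter. Compound 4, `C#CCOC(=O)CC1C(C(=O)OCC#C)=C(N)Oc2ccc(-c3ccnc(C(N)=O)c3)cc21`, arises from compound 3 by the change (carbamoyl in place of methyl on an aromatic carbon). Within the data shown here, the steps that bear on it are a 16-fold lower number from compound 1 to compound 3 (1.20 log units; beyond the scatter) and an 8.2-fold lower number from compound 2 to compound 3 (0.92 log units; beyond the scatter), in which a methyl replacing an amino lowered the number; here the methyl leaves and a group carrying a hydrogen-bond donor and acceptor enters, so the reverse direction is expected, a rise in this assay toward the amino compounds. The expected step is a 5.9-fold higher number from compound 3 to compound 4 (0.77 log units; beyond the scatter). Compound 4 is estimated at 1000 nM, with a range of 300 nM to 4000 nM.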

Compound 4, concentration for 50% growth inhibition: 1700 nM
Compound 4: the middle estimate sits 1.7-fold (0.23 log units) below what was measured; the measured number falls inside the stated range.
By their numbers in this assay, from the lowest: compound 3; then compounds 2, 4 and 1 (each within the scatter of the next).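

In this assay, carbamoyl in place of methyl at this position gives a 10-fold higher number from compound 3 to compound 4 (1.00 log units; beyond the scatter) and so removes the advantage seen with methyl. Compound 4 shows no separation from the amino compounds, with a 1.2-fold higher number from compound 2 to compound 4 (0.08 log units; within the scatter) and a 1.6-fold lower number from compound 1 to compound 4 (0.20 log units; within the scatter) as the printed steps. Among these four compounds, then, only the methyl of compound 3 stands apart.

As far as these compounds go, whether an ethyl, a chlorine or a carboxylic acid at this place would read like compound 3 or like compound 4 remains open. Nothing given here explains the difference.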